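The source may report more compounds than this note shows. Statements on the series, on what has been measured and on what is new or still open speak of the compounds shown alone.

Measured so far in an ADME assay on Huh-7 cells (Homo sapiens) for cytotoxicity, read by MTT assay, with a stated time of 48 h; a lower number here means that less compound is tolerated, a higher number that more compound is tolerated:

Compound 1 `CN(C)CCCCN(C(=O)O)c1ccc(Cn2nc(-c3ccc(F)cc3)c3ccccc3c2=O)cc1`: 19000 nM
Compound 2 `CN(C)CCCCC(=O)Nc1ccc(CN2N=C(c3ccc(F)cc3)C3C=CC=CC3C2=O)cc1`: 77700 nM
Compound 3 `CN(C)CCCCOC(=O)Nc1ccc(Cn2nc(-c3cncnc3)c3ccccc3c2=O)cc1`: 65300 nM

Among these three numbers compound 3 holds the second highest place. Its nearest neighbour is compound 2, whose value sits within the scatter of repeated measurements, so the two cannot be told apart on this evidence. Compound 1 stands furthest away, with a lower number, and that gap lies beyond the scatter: less of compound 1 was tolerated by the cells than of compound 3.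

The next compound to be tested, compound 4 `CN(C)CCCCOC(=O)Nc1ccc(Cn2nc(-c3ccncc3)c3ccccc3c2=O)cc1`, differs from compound 3 in a single spot: pyridin-4-yl in place of pyrimidin-5-yl on an aromatic carbon. Among the measured compounds shown here, the long chain, the carbamate link, the benzyl group and the shared core are all retained; only one ring nitrogen of the aryl group is taken away.

For the measured compounds named here, no step between two measured compounds isolates this kind of exchange, so there is no direct precedent for its size. With so little of the molecule altered, the step from compound 3 to compound 4 is expected to be small, a 1.2-fold lower number from compound 3 to compound 4 (0.07 log units; within the scatter), and not beyond the scatter in either direction. On that basis compound 4 is estimated to give about 55000 nM in this assay, within a range from 22000 nM to 140000 nM.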

Compound 4, half-maximal cytotoxic concentration: 62700 nM
The estimate for compound 4 lay 1.1-fold (0.06 log units) below the measured number, and the stated range covers the measured number.
By their numbers in this assay, from the lowest: compound 1; then compounds 4, 3 and 2 (each within the scatter of the next).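

In this assay, among the compounds shown here, putting pyridin-4-yl in place of pyrimidin-5-yl on this aromatic carbon of the shared core gives a 1.0-fold lower number from compound 3 to compound 4 (0.02 log units; within the scatter), the first direct reading of a single exchange at this position. Removing one ring nitrogen and one hydrogen-bond acceptor from the aryl group therefore makes no difference that can be told from the scatter, at least for this pair of compounds with the same carbamate link and long chain. No independent measurement accompanies this result, so it describes the outcome without offering any explanation for it.

The fluorophenyl group of compound 1 and compound 2 cannot be compared with these two aryl groups, since those compounds also differ from compound 3 and compound 4 elsewhere in the molecule. On these data alone, it also remains open whether this position would accept something much less like these rings, such as a carboxylic acid or a morpholine ring, with a number that stays within the scatter.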